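From 4-bromophenyl to 4-methylphenyl in a limit-bound series

The compounds below may be only part of what the source reports. "The series", "measured", "known", "first", "only" and "open" are said of these compounds alone.

Measured in an ADME assay on MDCK cells (Canis lupus familiaris) for cytotoxicity (a lower number here means that less compound is tolerated, a higher number that more compound is tolerated), all three values being limits:
Compound 1 `CC(=O)Nc1ccc2oc(-c3ccnc(C(=O)N4CCN(C(c5nnn(C)n5)c5ccccc5F)CC4)c3)nc2c1`: > 50000 nM
Compound 2 `CC(=O)Nc1ccc2oc(-c3ccnc(C(=O)N4CCN([C@H](c5ccc(F)cc5)c5nnn(C)n5)CC4)c3)nc2c1`: > 200000 nM
Compound 3 `CC(=O)Nc1ccc2oc(-c3ccnc(C(=O)N4CCN(C(c5ccc(Br)cc5)c5nnn(C)n5)CC4)c3)nc2c1`: > 50000 nM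

Compound 3 stands at the limit of > 50000 nM in this assay, at which 2 of the 3 values shown sit. Compound 2 stands at the limit of > 200000 nM in this assay, at which 1 of the 3 values shown sits. None of the three compounds has a readable number, so the series offers no measured size to carry forward.

Compound 4 `CC(=O)Nc1ccc2oc(-c3ccnc(C(=O)N4CCN(C(c5ccc(C)cc5)c5nnn(C)n5)CC4)c3)nc2c1` has methyl in place of bromo on an aromatic carbon, para to a large group (methyl in place of bromo on an aromatic carbon).

For the measured compounds named here, the one measured step at this aryl group is a step that the two limits leave unreadable from compound 1 to compound 3. It gives neither a size nor a direction. The expectation therefore rests on compound 3, whose > 50000 nM is a limit. No step beyond the scatter is expected in this assay, and the expected step is a step that the limit leaves unreadable from compound 3 to compound 4. A limit is the most likely report again. The estimate for compound 4 is 100000 nM, with an expected range from 40000 nM to 250000 nM.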

Compound 4, half-maximal cytotoxic concentration: > 50000 nM
Compound 4 gave a limit, no number; the forecaster's own chance of this, stated with the estimate: 90%; the middle value lies beyond the limit too.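

In this assay compound 4 gives > 50000 nM, a limit, so the steps to it from compound 3 and from compound 1 cannot be read. The compounds shown leave open whether the half-maximal cytotoxic concentration differs at all among these aryl groups.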